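Allyl in place of propyl on the chain at the aromatic nitrogen

This account rests on a few compounds, and the source may have more. Where it says the series, first, only, none or still open, it means among the compounds named here.

Three compounds share one core and differ only in the chain attached to the aromatic nitrogen. In a functional assay for antagonist activity at 5-hydroxytryptamine receptor 4 (Cavia porcellus) (on this read-out lower numbers stand for lower potency and higher numbers for higher potency (the scale is a negative logarithm)), compound 1 `CCn1c(=O)n(C(=O)NCCN2CCN(C)CC2)c2ccccc21` gives 6.79. Compound 2 `CCCn1c(=O)n(C(=O)NCCN2CCN(C)CC2)c2ccccc21` reaches only the limit of this assay, < 6. Compound 3 `CCCCn1c(=O)n(C(=O)NCCN2CCN(C)CC2)c2ccccc21` likewise stands at the limit, < 6. Both longer chains therefore lose potency against compound 1: a number at least 0.79 log units lower from compound 1 to compound 2 (beyond the scatter) and a number at least 0.79 log units lower from compound 1 to compound 3 (beyond the scatter). Between the two longer chains the step that the two limits leave unreadable from compound 2 to compound 3 cannot be read, since both values sit at the limit of < 6 in this assay, at which 2 of the 3 values shown sit.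

Compound 4 `C=CCn1c(=O)n(C(=O)NCCN2CCN(C)CC2)c2ccccc21` is the next change, (vinyl in place of propyl on a saturated chain carbon bound to an aromatic nitrogen). The chain keeps the length of compound 2 but carries a double bond. Within the data shown here, no measured step tests a double bond here; the nearest evidence is that a three-carbon chain in compound 2 already sits at the limit. The expected step that the limit leaves unreadable from compound 3 to compound 4 is therefore small or none beyond the scatter. Compound 4 is estimated at 5.9, within 5.3 to 6.5, with a good chance that this assay again reports only a limit.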

Compound 4, negative logarithm of the antagonist equilibrium constant: < 6
Compound 4 ended at the assay's limit (the forecaster's own chance of this, stated with the estimate: 60%); the middle value lies beyond the limit too.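

Compound 4 gives < 6 in this assay, which is a limit of the assay and not a number. A double bond in the chain therefore does not bring back the potency of the shorter ethyl chain, as the allyl chain gives a number at least 0.79 log units lower from compound 1 to compound 4 (beyond the scatter). The steps from compound 2 and compound 3 to compound 4 cannot be read, because these compounds all sit at the same boundary: the limit of < 6 in this assay, at which 3 of the 4 values shown sit.

On these data alone, whether the allyl chain differs at all from the propyl or butyl chain remains open, since the true potencies of these three compounds lie out of view. Also open, as far as these compounds go, is whether a methyl group, or an ethyl chain ending in a hydroxyl group or an amine, on the aromatic nitrogen would match or pass compound 1.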